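Chloro for trifluoromethyl on the aryl urea end

This account rests on a few compounds, and the source may have more. Where it says the series, first, only, none or still open, it means among the compounds named here.

Compound 1 `O=C(Nc1ccc(Oc2ccc(-c3nccs3)cc2)cc1)Nc1ccc(F)c(Cl)c1`: 37.3%
Compound 2 `O=C(Nc1ccccc1)Nc1ccc(Oc2ccc(-c3ncc[nH]3)cc2)cc1`: 7.09%
Compound 3 `O=C(Nc1ccc(Oc2ccc(-c3ncc[nH]3)cc2)cc1)Nc1ccc(F)c(C(F)(F)F)c1`: 63.3%

In a functional assay on A549 cells (Homo sapiens) for inhibition, read by MTT assay and WST assay, with a stated time of 72 h, tested at 10 uM (on this read-out lower numbers stand for less inhibition of growth and higher numbers for more inhibition of growth at the one concentration tested), compound 3 stands highest of the three; compound 1 sits lower and compound 2 lowest, each beyond the scatter. The step of a number 56.2 percentage points higher from compound 2 to compound 3 (beyond the scatter) shows that a substituted aryl on the urea nitrogen matters greatly here. Compound 4 `O=C(Nc1ccc(Oc2ccc(-c3ncc[nH]3)cc2)cc1)Nc1ccc(F)c(Cl)c1` is not yet measured; it differs from compound 3 by chloro in place of trifluoromethyl on an aromatic carbon. Going by the values given here, no measured step covers exactly this exchange, but compound 1, which carries the same 3-chloro-4-fluorophenyl group on a different core, gives 37.3%. Compound 4 is therefore expected to stay active yet fall somewhat. The expected step is a number 16.3 percentage points lower from compound 3 to compound 4 (beyond the scatter). Compound 4 is estimated at 47% with an expected range of 28% to 66%.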

Compound 4, percent growth inhibition at one concentration: 14.6%
The estimate for compound 4 lay 32.4 percentage points above the measured number; the whole stated range lies above it.
By their numbers in this assay, from the lowest: compounds 2 and 4 (each within the scatter of the next); then compound 1; then compound 3.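

In this assay, trifluoromethyl at this position cannot be swapped for chloro without a large loss, with a number 48.7 percentage points lower from compound 3 to compound 4 (beyond the scatter). The 3-chloro-4-fluorophenyl group also fails to separate from plain phenyl, with a number 7.5 percentage points higher from compound 2 to compound 4 (within the scatter), so the earlier gain belongs to 4-fluoro-3-(trifluoromethyl)phenyl and not to any substituted aryl. This aryl group's effect also depends on the core, with a number 22.7 percentage points lower from compound 1 to compound 4 (beyond the scatter) when 1H-imidazol-2-yl replaces 1,3-thiazol-2-yl.

Nothing available explains why the two groups differ. Still open, on these data alone, is how a bromo, methyl or nitrile group would read at this position.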